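The compounds below may be only part of what the source reports. "The series", "measured", "known", "first", "only" and "open" are said of these compounds alone.

Compound 2 `C[C@H](Nc1c(C(=O)NCc2ccc(F)cc2)nc(Br)c2cccnc12)c1ccccc1` carries a 1-phenylethyl group on a nitrogen on an aromatic ring. In a functional assay on HCT-116 cells (Homo sapiens) for cytotoxicity, read by MTT assay, with a stated time of 72 h (a higher number here means a weaker inhibitor, a lower number a stronger inhibitor), compound 2 gives > 20000 nM, which is a limit of the assay, (the limit of > 20000 nM in this assay, at which 1 of the 3 values shown sits). Compound 1 `CNCCCNc1c(C(=O)NCc2ccc(F)cc2)nc(Br)c2cccnc12`, with 3-(methylamino)propyl on that same nitrogen, gives 9000 nM in this assay, so an at least 2.2-fold higher number from compound 1 to compound 2 (0.34 log units; beyond the scatter). Compound 3 `CC(C)(C)OC(=O)N1CCN(c2c(C(=O)NCc3ccc(F)cc3)nc(Br)c3cccnc23)CC1` gives > 10000 nM in this assay, also a limit, (the limit of > 10000 nM in this assay, at which 1 of the 3 values shown sits). Compound 4 `O=C(NCc1ccc(F)cc1)c1nc(Br)c2cccnc2c1NCCO` differs from compound 2 by 2-hydroxyethyl in place of 1-phenylethyl on a nitrogen on an aromatic ring. For the measured compounds named here, only one measured step bears on this change, an at least 2.2-fold higher number from compound 1 to compound 2 (0.34 log units; beyond the scatter), and it runs the other way, from a small chain to 1-phenylethyl. Reversing that direction, compound 4 is expected to give about 10000 nM, estimated between 3000 nM and 30000 nM. That expectation amounts to an at least 2.0-fold lower number from compound 2 to compound 4 (0.30 log units; that floor lies within the scatter).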

Compound 4, half-maximal inhibitory concentration: > 20000 nM
Compound 4: only a limit was reported; the forecaster's own chance of this, stated with the estimate: 40%; middle value at least 2.0-fold (0.30 log units) from the limit.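

On this nitrogen, compound 4, with its small 2-hydroxyethyl group, gives > 20000 nM in this assay, which is a limit and not a number. Hydroxy in place of (methylamino)methyl on the chain brings an at least 2.2-fold higher number from compound 1 to compound 4 (0.34 log units; beyond the scatter) in this assay, so this chain does not keep the measured activity of the amine-bearing chain. Compound 2 and compound 4 both sit at limits, so the step between them cannot be read. Still open, going by these compounds, is how a chain ending in a primary amine, or a longer chain ending in methylamino, would behave in this assay on this nitrogen.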